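Thiophen-3-yl for thiophen-2-yl across two cores

This account rests on a few compounds, and the source may have more. Where it says the series, first, only, none or still open, it means among the compounds named here.

Compound 1 `CC1=C(C(=O)OC(C)(C)C)C(c2cccs2)NC(=O)N1` and compound 2 `CC1=C(C(=O)OC(C)(C)C)C(c2ccsc2)NC(=O)N1` share a core and differ only in the aryl group on the saturated ring carbon; the change between them is thiophen-3-yl in place of thiophen-2-yl on a saturated ring carbon. In an assay on membranes from HEK293 cells for displacement of a labelled ligand from adenosine receptor A2b (Homo sapiens), read by scintillation counting, with a stated time of 30 min, tested at 1 uM (a lower number here means less inhibition, a higher number more inhibition at the concentration tested (going by the name of the read-out)), compound 1 gives 38% and compound 2 gives 47%, so the step of a number 9 percentage points higher from compound 1 to compound 2 (within the scatter) is small. Compound 3 `CCC(CC)OC(=O)C1=C(C)NC(=O)NC1c1cccs1` carries a different ester group; the difference from compound 1 is pentan-3-yl in place of tert-butyl on an oxygen next to a carbonyl group, and in this assay compound 3 gives 6%, the step of a number 32 percentage points lower from compound 1 to compound 3 (beyond the scatter) being the largest movement among the three measured compounds. Compound 4 `CCC(CC)OC(=O)C1=C(C)NC(=O)NC1c1ccsc1` is not yet measured; it stands to compound 3 as compound 2 stands to compound 1, the change being (thiophen-3-yl in place of thiophen-2-yl on a saturated ring carbon). The surroundings are not identical: in compound 3 the ring atom next to the place bears a group of 8 heavy atoms, in compound 1 one of 7 heavy atoms, so this is the same kind of change rather than the same one. The step from compound 3 to compound 4 in this assay is expected to be a number 7 percentage points higher from compound 3 to compound 4 (within the scatter), small like the earlier one, because a number 9 percentage points higher from compound 1 to compound 2 (within the scatter) stayed within the scatter. For compound 4 the expected value is 13%, between 0% and 30%.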

Compound 4, a percentage reported as inhibition, at one concentration (the size of the read-out at that concentration, not a potency): 26%
For compound 4 the middle estimate is 13 percentage points below the measured one, and the stated range covers the measured number.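

In this assay, thiophen-3-yl in place of thiophen-2-yl gives a number 20 percentage points higher from compound 3 to compound 4 (beyond the scatter), and this step does not differ from the one on the core of compound 1 by more than the scatter allows: the same change on two cores in this assay, a number 9 percentage points higher (within the scatter) from compound 1 to compound 2 and a number 20 percentage points higher (beyond the scatter) from compound 3 to compound 4, 11 percentage points apart, within the scatter of two such steps. Pentan-3-yl in place of tert-butyl gives a number 21 percentage points lower from compound 2 to compound 4 (beyond the scatter), and this step also matches its earlier counterpart: the same change on two cores in this assay, a number 32 percentage points lower (beyond the scatter) from compound 1 to compound 3 and a number 21 percentage points lower (beyond the scatter) from compound 2 to compound 4, 11 percentage points apart, within the scatter of two such steps. Among the compounds shown here, this supports carrying either change between these two cores, but it rests on only two pairs for each change, one thiophene step lies within the scatter, and percentages at one concentration do not show how potency shifts.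

Still open, as far as these compounds go, is how the read-out responds to a phenyl or furan-3-yl group on the saturated ring carbon, or to a straight pentyl chain on the ester oxygen. Also open, from the compounds shown here alone, is whether the two changes would combine in the same way with an amine or a carboxylic acid elsewhere on the shared core.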